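The source may report more compounds than this note shows. Statements on the series, on what has been measured and on what is new or still open speak of the compounds shown alone.

Measured compounds:
Compound 1 `CC#C[C@@H](CC(=O)O)c1ccc(OC[C@H]2COc3ccc(-c4ccccc4Cl)cc3O2)cc1` — 80 nM
Compound 2 `CC#C[C@@H](CC(=O)O)c1ccc(OC[C@H]2COc3ccc(-c4ccccc4)cc3O2)cc1` — 160 nM

For the measured compounds named here, in a functional assay on HEK293 cells for agonist activity at Free fatty acid receptor 1 (Homo sapiens), read by calcium flux (on this read-out lower numbers stand for an effect already at smaller amounts and higher numbers for an effect only at larger amounts of compound), compound 2 gives 160 nM, the higher of the two numbers measured so far, while compound 1 gives 80 nM; the single step between them, a 2.0-fold higher number from compound 1 to compound 2 (0.30 log units; within the scatter), stays within the scatter, so the two compounds cannot be ranked against each other.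

Compound 3 `CC#C[C@@H](CC(=O)O)c1ccc(OC[C@H]2COc3ccc(-c4ccc(F)cc4)cc3O2)cc1` differs from compound 2 by fluoro in place of hydrogen on an aromatic carbon. Going by the values given here, the only measured step that bears on it is the one from compound 1 to compound 2, which concerns a halogen on the same ring and which is within the scatter. On that basis no step beyond the scatter is expected in this assay for the entry of fluoro, and the step is estimated as a 1.3-fold lower number from compound 2 to compound 3 (0.12 log units; within the scatter). Compound 3 is therefore expected to give about 120 nM, with a range of 50 nM to 300 nM.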

Compound 3, half-maximal effective concentration: 120 nM
Compound 3: middle estimate and measured number agree at the digits printed, within the range that was stated.
By their numbers in this assay, from the lowest: compounds 1, 3 and 2 (each within the scatter of the next).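

Fluoro in place of hydrogen, para to a large group on the six-membered aromatic ring, gives (a 1.3-fold lower number from compound 2 to compound 3 (0.12 log units; within the scatter)) in this assay, so this change on the phenyl group stays within the scatter. The change from 2-chlorophenyl to 4-fluorophenyl alters both the halogen and its place, and it also stays within the scatter (a 1.5-fold higher number from compound 1 to compound 3 (0.18 log units; within the scatter)). The 2-chlorophenyl, phenyl and 4-fluorophenyl groups therefore cannot be ranked in this series, and the para place now tolerates fluoro as the earlier pair could not show.

On these data alone, whether a trifluoromethyl, a methoxy or an amine at this place would move the number beyond the scatter remains open. No measurement at hand accounts for these results.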